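A few compounds are considered here, and "the series" means these few. Any claim that something is new, unique, unknown or untested is made for them only; others in the source may bear on it.

Compound 1 `Nc1ccc(-c2cc(=O)c3c(N)c(F)cc(F)c3o2)cc1F`: in a functional assay on HeLa cells (Homo sapiens) for cytotoxicity, read by neutral red uptake, with a stated time of 3 days (a lower number here means a stronger inhibitor, a higher number a weaker inhibitor), the value is reported as a limit, > 100000 nM.
Compound 2 `Nc1ccc(-c2cc(=O)c3c(N)c(F)c(Cl)c(F)c3o2)cc1F`: in this assay the value is reported as a limit, > 100000 nM.

Compound 2 therefore stands at the edge of what this assay can resolve, with no number of its own. Among the compounds with values here, the one measured step that touches it, a step that the two limits leave unreadable from compound 1 to compound 2, cannot be read in either direction because of the limit of > 100000 nM in this assay, at which 2 of the 2 values shown sit. Compound 3 `CCOC(=O)c1c(F)c(N)c2c(=O)cc(-c3ccc(N)c(F)c3)oc2c1F` differs from compound 2 by ethoxycarbonyl in place of chloro on an aromatic carbon. Within the data shown here, the only measured step that bears on this change is that unreadable one, so the data give no direction and no size to expect; the expectation can only be that compound 3 again sits where compound 2 sits. The step from compound 2 to compound 3 is thus estimated as a step that the limit leaves unreadable from compound 2 to compound 3. On that basis compound 3 is expected to give about 150000 nM in this assay, most likely reported as a limit, within a range of 30000 nM to 1000000 nM.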

Compound 3, half-maximal inhibitory concentration: > 100000 nM
Compound 3 ended at the assay's limit (the forecaster's own chance of this, stated with the estimate: 85%); the middle value is on the limit's open side.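

In this assay compound 3 also gives only a limit, > 100000 nM. No step among compound 1, compound 2 and compound 3 can be read, because all three stop at the same point: the limit of > 100000 nM in this assay, at which 3 of the 3 values shown sit.

The compounds shown leave open whether hydrogen, chloro or ethoxycarbonyl on that aromatic carbon makes any difference in this assay.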